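The compounds below may be only part of what the source reports. "The series", "measured", "known", "first", "only" and "open" are said of these compounds alone.

Going by the values given here, compound 2 `COc1cccc(CNCCCNc2ccnc3cc(Cc4cccc(C(F)(F)F)c4)ccc23)c1O` is one of two compounds measured in an ADME assay for permeability, using PAMPA, with a stated time of 30 min, at pH 7.4 (a higher number here means that the compound crosses the layer faster, a lower number that the compound crosses the layer more slowly), where compound 2 gives 23 10^-6 cm/s. Compound 1 `COc1ccc(Oc2ccc3c(NCCCNCc4cccc(OC)c4O)ccnc3c2)cc1` differs from it in one place, and in this assay compound 1 gives 317 10^-6 cm/s. So compound 2 stands as the lower of the two numbers, and the one recorded step, from compound 1 to compound 2, is a 14-fold lower number from compound 1 to compound 2 (1.14 log units; beyond the scatter).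

The new compound 3 `COc1ccccc1Oc1ccc2c(NCCCNCc3cccc(OC)c3O)ccnc2c1` again changes the same place on an aromatic carbon: 2-methoxyphenoxy in place of 3-(trifluoromethyl)benzyl on an aromatic carbon. The group that enters is an aryl ether carrying a methoxy group, much like the 4-methoxyphenoxy group of compound 1, and the group that leaves is the same 3-(trifluoromethyl)benzyl that went with the low number of compound 2. Among the compounds with values here, the step from compound 1 to compound 2 is the only guide here; it was large, and compound 3 is expected to reverse most of it, with a large upward step of about an 11-fold higher number from compound 2 to compound 3 (1.04 log units; beyond the scatter) in this assay. Compound 3 is therefore estimated at 250 10^-6 cm/s, within a range from 100 10^-6 cm/s to 500 10^-6 cm/s, in this assay.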

Compound 3, apparent permeability: 317 10^-6 cm/s
Compound 3: middle estimate off by 1.3-fold (0.10 log units), on the low side, within the range that was stated.
By their numbers in this assay, from the lowest: compound 2; then compounds 1 and 3 (each within the scatter of the next).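

In this assay the change from 3-(trifluoromethyl)benzyl to 2-methoxyphenoxy on the same aromatic carbon gives a 14-fold higher number from compound 2 to compound 3 (1.14 log units; beyond the scatter) and equals in size the earlier fall, a 14-fold lower number from compound 1 to compound 2 (1.14 log units; beyond the scatter) at that carbon. Moving the methoxy group on the outer ring, with 2-methoxyphenyl in place of 4-methoxyphenyl on an oxygen on an aromatic ring, gives no change at the digits printed from compound 1 to compound 3 (within the scatter) in this assay, so this shift of the methoxy group leaves the number where it was. Among these three compounds, the low number belongs only to the one carrying 3-(trifluoromethyl)benzyl, while the two methoxyphenoxy compounds share the same higher number.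

Going by these compounds, compound 2 differs from the other two both in the link to the core, a carbon rather than an oxygen, and in the group on the outer ring, so it stays open which of these goes with the low number; a 3-(trifluoromethyl)phenoxy or a methoxybenzyl group would separate the two, and an amine or a carboxylic acid on the outer ring remains an open case. Nothing shown here gives a measured reason for these differences.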